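Cytotoxicity limits across a pyridazinone sulfonamide series

This account rests on a few compounds, and the source may have more. Where it says the series, first, only, none or still open, it means among the compounds named here.

Three compounds sharing a pyridazinone core were profiled in an ADME assay on Huh-7 cells (Homo sapiens) for cytotoxicity, with a stated time of 72 h; on this read-out higher numbers stand for lower toxicity in this test and lower numbers for higher toxicity in this test. Compound 1 `CCS(=O)(=O)Nc1ccc2c(c1)S(=O)(=O)N=C(c1c(O)c(-c3cccs3)nn(CCC(C)C)c1=O)N2` carries an ethylsulfonyl amide and a 3-methylbutyl chain. In this assay compound 1 gives > 33000 nM, which is a limit of the assay and not a number. Compound 2 `CC(C)CCn1nc(-c2cccs2)c(O)c(C2=NS(=O)(=O)c3cc(NS(=O)(=O)C(C)C)ccc3N2)c1=O` differs from compound 1 by methyl in place of hydrogen on a saturated chain carbon bound to a saturated chain carbon and a sulfonyl sulfur. In this assay compound 2 gives > 1000 nM, again a limit rather than a number. The step that the two limits leave unreadable from compound 1 to compound 2 therefore cannot be read, because both values sit at limits, the limit of > 1000 nM in this assay, at which 1 of the 3 values shown sits, and (the limit of > 33000 nM in this assay, at which 2 of the 3 values shown sit). Compound 3 `CCCC(C)n1nc(-c2cccs2)c(O)c(C2=NS(=O)(=O)c3cc(NS(C)(=O)=O)ccc3N2)c1=O` has a different core from compound 1; that difference between the two cores is not broken down here. In this assay compound 3 gives > 33000 nM, which is a limit of the assay and not a number.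

Compound 4 `CC(C)CC(C)n1nc(-c2cccs2)c(O)c(C2=NS(=O)(=O)c3cc(NS(C)(=O)=O)ccc3N2)c1=O` has not yet been measured. It differs from compound 3 by methyl in place of hydrogen on a saturated chain carbon bound to two saturated chain carbons. This is the same kind of change as that from compound 1 to compound 2, but the place differs: there the carbon was bound to a saturated chain carbon and a sulfonyl sulfur, here it is bound to two saturated chain carbons. Since the step in this assay from compound 1 to compound 2 could not be read, and compound 3 sits at a limit, compound 4 is expected to show a step that the limit leaves unreadable from compound 3 to compound 4, resting on compound 3 at > 33000 nM. In this assay compound 4 is estimated at 50000 nM, between 20000 nM and 150000 nM, most likely reported as a limit.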

Compound 4, half-maximal cytotoxic concentration: > 33000 nM
Compound 4 was reported as a limit; the forecaster's own chance of this, stated with the estimate: 85%; the middle value does not contradict the limit.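

No new step can be read from compound 4: the step from compound 3 to compound 4 stays unreadable, because both compounds sit at the same limit of the assay, and neither value is a number: the limit of > 33000 nM in this assay, at which 3 of the 4 values shown sit.

The compounds shown leave open how far any of them lies beyond its limit, and so whether methyl in place of hydrogen changes this read-out at all.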